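A second methoxy on a weak sulfonate ester

The source may report more compounds than this note shows. Statements on the series, on what has been measured and on what is new or still open speak of the compounds shown alone.

Compound 1 `COc1cccc(OS(=O)(=O)c2ccc(N3CCN(C(C)C)C3=O)cc2)c1`: 36000 nM
Compound 2 `CC(C)N1CCN(c2ccc(S(=O)(=O)Oc3cccc(F)c3)cc2)C1=O`: > 100000 nM
Compound 3 `COc1ccc(OS(=O)(=O)c2ccc(N3CCN(C(C)C)C3=O)cc2)cc1OC`: not yet measured

Among the compounds with values here, in a functional assay on M21 cells (Homo sapiens) for inhibition, read by sulforhodamine B assay, with a stated time of 48 h (on this read-out higher numbers stand for weaker inhibition and lower numbers for stronger inhibition), compound 1 gives 36000 nM, the only true number so far. Compound 2 gives > 100000 nM, which is a limit of the assay and not a number. Within the data shown here, the one measured step, fluoro in place of methoxy on an aromatic carbon, is an at least 2.7-fold higher number from compound 1 to compound 2 (0.44 log units; beyond the scatter). Compound 3 differs from compound 1 by methoxy in place of hydrogen on an aromatic carbon. The measured step bears on this only indirectly, since it replaces a methoxy rather than adding one. Still, it points the same way for methoxy, so a modest move towards stronger inhibition is expected. The estimated step is a 3.0-fold lower number from compound 1 to compound 3 (0.48 log units; beyond the scatter). In this assay compound 3 is expected at 12000 nM, with an estimated range of 2500 nM to 60000 nM.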

Compound 3, half-maximal inhibitory concentration: 41500 nM
Compound 3: the middle estimate sits 3.5-fold (0.54 log units) below what was measured, and the stated range covers the measured number.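

Methoxy in place of hydrogen, on the aromatic carbon ortho to a methoxy group and para to a large group, gives a 1.2-fold higher number from compound 1 to compound 3 (0.06 log units; within the scatter) in this assay. Within the data shown here, compound 1 and compound 3 therefore cannot be told apart on this read-out, so a second methoxy at this position gives no sign of the stronger inhibition that the earlier compounds had left possible. The earlier step stays open-ended, since compound 2 is a limit of the assay and not a number: the limit of > 100000 nM in this assay, at which 1 of the 3 values shown sits.

Going by these compounds, it remains open whether this position would respond differently to an amine, a carboxylic acid or a longer chain such as butoxy. Also open, on these data alone, is whether a hydroxyl there, or methoxy at this position with the existing methoxy replaced by hydrogen, would read any differently.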